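This account rests on a few compounds, and the source may have more. Where it says the series, first, only, none or still open, it means among the compounds named here.

Measured so far:
- compound 1, `Nc1ccccc1NC(=O)c1ccc(CNCc2nc(-c3cccs3)no2)cc1`: > 10000 nM in an assay on isolated protein for inhibition of histone deacetylase 8 (Homo sapiens), read by fluorescence, with a stated time of 20 min; on this read-out higher numbers stand for weaker inhibition and lower numbers for stronger inhibition
- compound 2, `O=C(NO)c1ccc(CNCc2nc(-c3ccc([N+](=O)[O-])cc3)no2)cc1`: 380 nM

Of the compounds shown here, two have been measured in this assay. Compound 1 gives > 10000 nM, which is a limit of the assay and not a number, as recorded in the limit of > 10000 nM in this assay, at which 1 of the 2 values shown sits. Compound 2 gives 380 nM in this assay. On the numbers shown, compound 2 therefore holds the only value that is a number; the one other result is a limit.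

Compound 3, `O=C(NO)c1ccc(CNCc2nc(-c3cccs3)no2)cc1`, has not yet been measured in this assay. It differs from compound 2 by thiophen-2-yl in place of 4-nitrophenyl on an aromatic carbon. Going by the values given here, no step between two measured compounds that differ in one place exists here, so the size of this step has no measured counterpart. The account expects a step of modest size in this assay, toward weaker inhibition, and possibly not beyond the scatter. The estimate for compound 3 is 650 nM, with a range from 150 nM to 2800 nM. The expected step is a 1.7-fold higher number from compound 2 to compound 3 (0.23 log units; within the scatter).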

Compound 3, half-maximal inhibitory concentration: 8260 nM
Compound 3: the middle estimate sits 13-fold (1.10 log units) below what was measured; the whole stated range lies below it.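

In this assay, the place on the five-membered aromatic ring with 2 nitrogen and 1 oxygen, between two ring nitrogen atoms, now has its first measured step, and the choice of group there matters: thiophen-2-yl in place of 4-nitrophenyl gives a 22-fold higher number from compound 2 to compound 3 (1.34 log units; beyond the scatter). With thiophen-2-yl held at that place, hydroxy in place of 2-aminophenyl on the amide-type nitrogen gives an at least 1.2-fold lower number from compound 1 to compound 3 (0.08 log units; that floor lies within the scatter), so this pair shows no change that can be told from the scatter. The result for compound 1 is a limit of the assay and not a number: the limit of > 10000 nM in this assay, at which 1 of the 3 values shown sits.

The compounds shown do not separate the part played by the nitro group from that of the six-membered ring, since phenyl, which would lie on that path, does not stand among them at this place, and neither does a 4-aminophenyl or 4-methoxyphenyl group. They also leave open how 2-aminophenyl on the amide-type nitrogen behaves when 4-nitrophenyl occupies the place on the five-membered ring.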